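A few compounds are considered here, and "the series" means these few. Any claim that something is new, unique, unknown or untested is made for them only; others in the source may bear on it.

Compound 1, `COc1cc(-c2cc(/C=C/C(=O)c3ccc(Cl)c(Cl)c3)[nH]n2)cc(OC)c1OC`, in a functional assay on U-251 cells (Homo sapiens) for cytotoxicity, read by sulforhodamine B assay, with a stated time of 48 h, tested at 10 uM (on this read-out higher numbers stand for a weaker effect at the one concentration tested and lower numbers for a stronger effect), gives 48%.
Compound 2, `COc1ccc(C(=O)/C=C/c2cc(-c3cc(OC)c(OC)c(OC)c3)n[nH]2)cc1OC`, gives in this assay -100%.
Compound 3, `COc1ccc(C(=O)/C=C/c2cc(-c3cc(OC)c(OC)c(OC)c3)n[nH]2)cc1`, gives in this assay -98%.

Among these three, compound 2 holds the lowest number, but its standing is split: compound 1 lies far from it, with a number 148 percentage points lower from compound 1 to compound 2 (beyond the scatter), whereas compound 3 sits within the scatter of it, as a number 2 percentage points higher from compound 2 to compound 3 (within the scatter) shows. The two large steps, a number 148 percentage points lower from compound 1 to compound 2 (beyond the scatter) and a number 146 percentage points lower from compound 1 to compound 3 (beyond the scatter), both come from exchanging the group on the carbonyl carbon, not from changing a methoxy pattern on the ring that carries it.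

Compound 4, `COc1cc(C(=O)/C=C/c2cc(-c3cc(OC)c(OC)c(OC)c3)n[nH]2)cc(OC)c1OC`, has not yet been measured in this assay. It differs from compound 2 in one place: methoxy in place of hydrogen on an aromatic carbon. The change sits on the same six-membered aromatic ring of carbon only where compound 3 lost a methoxy relative to compound 2, and that loss moved the read-out by a number 2 percentage points higher from compound 2 to compound 3 (within the scatter) only. Among the compounds with values here, the one measured step that bears on adding or removing a methoxy on this ring is thus within the scatter, so no step beyond the scatter is expected in this assay for compound 4, in either direction. Compound 4 is therefore estimated at -97%, in the range -115% to -60%, which means an expected step of a number 3 percentage points higher from compound 2 to compound 4 (within the scatter).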

Compound 4, a percentage reported as activity, at one concentration (the size of the read-out at that concentration, not a potency): -94%
Compound 4: the middle estimate sits 3 percentage points below what was measured; the measured number falls inside the stated range.
By their numbers in this assay, from the lowest: compounds 2, 3 and 4 (each within the scatter of the next); then compound 1.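

In this assay, the added methoxy, on an aromatic carbon ortho to a methoxy group and meta to a large group, gives a number 6 percentage points higher from compound 2 to compound 4 (within the scatter). This adds a step in the adding direction to the removal of a methoxy from the same ring in a number 2 percentage points higher from compound 2 to compound 3 (within the scatter), and neither step leaves the scatter, so among compounds 2, 3 and 4 this ring takes a methoxy at this further position with no change that the read-out can separate, while the large difference in the set remains the exchange of the whole group on the carbonyl carbon, as in a number 148 percentage points lower from compound 1 to compound 2 (beyond the scatter). No measured evidence is available that bears on this result.

The compounds shown leave open whether this tolerance belongs to methoxy alone or would extend to a hydroxy group, an amine, a carboxylic acid or a longer chain such as butoxy at the same position. With one concentration as the only read-out, they also leave open whether the effects of compounds 2, 3 and 4 would stay within the scatter of one another at other concentrations.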